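This account rests on a few compounds, and the source may have more. Where it says the series, first, only, none or still open, it means among the compounds named here.

Measured compounds:
Compound 1 `O=C(/C=C/c1ccc2c(c1)B(O)OC2)c1cccnc1`, which in a toxicity assay on MCF-10A cells (Homo sapiens) for cytotoxicity, read by MTT assay, with a stated time of 48 h (a higher number here means a weaker inhibitor, a lower number a stronger inhibitor), gives 34400 nM.
Compound 2 `Nc1ccc(C(=O)/C=C/c2ccc3c(c2)B(O)OC3)cc1`, which in this assay gives 19900 nM.

Compound 2 stands next to compound 1 on the numbers shown, and the two cannot be told apart: the only measured step, a 1.7-fold lower number from compound 1 to compound 2 (0.24 log units; within the scatter), falls within the scatter of repeated measurements. So far, then, swapping one six-membered aromatic ring on the carbonyl carbon for another has left the number where it was.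

Compound 3 `O=C(/C=C/c1ccc2c(c1)B(O)OC2)c1cccc(O)c1` has not yet been measured in this assay. It differs from compound 2 in one place: 3-hydroxyphenyl in place of 4-aminophenyl on a carbonyl carbon. Within the data shown here, the only step that bears on this change is the one between compound 1 and compound 2, which exchanged rings at the same carbonyl carbon and moved the number by less than the scatter. On that basis no step beyond the scatter is expected, and the estimate for the step from compound 2 to compound 3 is a 1.3-fold higher number from compound 2 to compound 3 (0.10 log units; within the scatter). For compound 3 the expected value in this assay is 25000 nM, with a range from 10000 nM to 60000 nM.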

Compound 3, half-maximal inhibitory concentration: 25300 nM
Compound 3: middle estimate off by 1.0-fold (0.01 log units), on the low side, and the stated range covers the measured number.
By their numbers in this assay, from the lowest: compounds 2, 3 and 1 (each within the scatter of the next).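

With compound 3, the comparison at this carbonyl carbon in this assay now covers three six-membered aromatic rings, and no two can be told apart: a 1.3-fold higher number from compound 2 to compound 3 (0.10 log units; within the scatter) and a 1.4-fold lower number from compound 1 to compound 3 (0.13 log units; within the scatter) both lie within the scatter. The earlier pair compared only pyridin-3-yl with 4-aminophenyl, whereas these steps extend the same result to 3-hydroxyphenyl, so an amino group on one ring and a hydroxyl group on the other give numbers that cannot be separated, although the two groups are named at different ring positions. No available evidence accounts for this lack of separation.

On these data alone, whether any group on this carbonyl carbon can move the number beyond the scatter remains open, since all three compounds carry a six-membered aromatic ring there, and a piperidine, a carboxylic acid or a longer alkyl chain would be a more distant replacement. The three compounds also leave open whether the same hydroxyl or amino group would give a different number at another ring position, and they say nothing about changes to the shared core.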